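A few compounds are considered here, and "the series" means these few. Any claim that something is new, unique, unknown or untested is made for them only; others in the source may bear on it.

Of the compounds shown here, three sharing one core have been measured in an assay on isolated protein for activation of Nicotinamide phosphoribosyltransferase (Homo sapiens); on this read-out higher numbers stand for an effect only at larger amounts of compound and lower numbers for an effect already at smaller amounts. Compound 1 `O=C(NCc1ccncc1)Nc1ccc(S(=O)(=O)Nc2ccccc2)cc1` gives 410 nM, compound 2 `CCN(CC)S(=O)(=O)c1ccc(NC(=O)NCc2ccncc2)cc1` gives 384 nM, and compound 3 `O=C(NCc1ccncc1)Nc1ccc(S(=O)(=O)c2ccccc2)cc1` gives 85 nM, the lowest of the three numbers: a 4.8-fold lower number from compound 1 to compound 3 (0.68 log units; beyond the scatter) and a 4.5-fold lower number from compound 2 to compound 3 (0.65 log units; beyond the scatter). Compound 4 `O=C(NCc1ccncc1)Nc1ccc(S(=O)(=O)c2cccc(Cl)c2)cc1` differs from compound 3 in one place only: chloro in place of hydrogen on an aromatic carbon. The two measured steps leading to compound 3 change the group on the sulfonyl sulfur itself, not a substituent on that phenyl, and neither bears directly on the present change. With nothing measured to guide it, the step in this assay is expected to stay within the scatter, a 1.2-fold lower number from compound 3 to compound 4 (0.08 log units; within the scatter). Compound 4 is estimated at 70 nM, with a range from 25 nM to 200 nM.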

Compound 4, half-maximal effective concentration: 69 nM
Compound 4: middle estimate off by 1.0-fold (0.01 log units), on the high side, and the stated range covers the measured number.
By their numbers in this assay, from the lowest: compounds 4 and 3 (each within the scatter of the next); then compounds 2 and 1 (each within the scatter of the next).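

In this assay, this first change on the phenyl attached to the sulfonyl sulfur gives a 1.2-fold lower number from compound 3 to compound 4 (0.09 log units; within the scatter), so adding a chloro at this position leaves the number within the scatter. The replacements on the sulfonyl sulfur remain beyond the scatter with 3-chlorophenyl as the new group: a 5.6-fold lower number from compound 2 to compound 4 (0.75 log units; beyond the scatter) and a 5.9-fold lower number from compound 1 to compound 4 (0.77 log units; beyond the scatter). No supporting measurement is available to explain these results. Still open, from the compounds shown here alone, is whether a methoxy group or an amine at this position, or a chloro elsewhere on this ring, would shift the number beyond the scatter.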